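The source may report more compounds than this note shows. Statements on the series, on what has been measured and on what is new or still open speak of the compounds shown alone.

Compound 1 `CC(=O)Nc1cc(NC(=O)Nc2ccccc2Cl)ccc1C` is one of three measured compounds. In a functional assay on A375P cells (Homo sapiens) for antiproliferative activity (a higher number here means a weaker inhibitor, a lower number a stronger inhibitor), compound 1 gives > 30000 nM, which is a limit of the assay and not a number.
Compound 2 `CC(=O)Nc1cc(NC(=O)Nc2cc(C(F)(F)F)cc(C(F)(F)F)c2)ccc1C` is the second. In this assay compound 2 gives 685 nM.
Compound 3 `Cc1ccc(NC(=O)Nc2ccccc2Cl)cc1NC(=O)c1ccccc1` is the third. In this assay compound 3 gives > 30000 nM, again a limit rather than a number.

Going by the values given here, compound 2 thus holds the only real number here; the other two values sit at the limit of > 30000 nM in this assay, at which 2 of the 3 values shown sit. Compound 1 and compound 3 differ in one place: phenyl in place of methyl on a carbonyl carbon. The size of that step, a step that the two limits leave unreadable from compound 1 to compound 3, cannot be read, because both values are limits. How the core of compound 1 differs from the core of compound 2 is not broken down here.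

Compound 4 `Cc1ccc(NC(=O)Nc2cc(C(F)(F)F)cc(C(F)(F)F)c2)cc1NC(=O)c1ccccc1` has not yet been measured. It stands to compound 2 as compound 3 stands to compound 1: phenyl in place of methyl on a carbonyl carbon. The place is described in the same words for both pairs, so this is the same change made on a different core.

Among the compounds with values here, what can be expected for compound 4 rests on the value of compound 2, 685 nM, and on the fact that the only measured example of this change gave no readable size. With nothing to argue for a large shift in either direction, the step from compound 2 to compound 4 is expected to be modest, a 1.0-fold higher number from compound 2 to compound 4 (0.01 log units; within the scatter). Compound 4 is therefore estimated at 700 nM, with a likely range from 150 nM to 3500 nM.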

Compound 4, half-maximal inhibitory concentration: 162 nM
Compound 4: middle estimate off by 4.3-fold (0.64 log units), on the high side; low and high end bracket the measured number.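

Putting phenyl in place of methyl on a carbonyl carbon, the change from acetamido to benzamido, gives in this assay a 4.2-fold lower number from compound 2 to compound 4 (0.63 log units; beyond the scatter), so on the core of compound 2 the larger group is accepted and goes with a lower number. On the core of compound 1, the same change gives no readable step, because the values of both compounds in that pair are limits of the assay and not numbers: the limit of > 30000 nM in this assay, at which 2 of the 4 values shown sit. The change therefore has one readable size in one core, which does not show that it carries from one core to another: a similar drop on the core of compound 1 is neither shown nor ruled out, and nothing here explains the drop on the core of compound 2.

The compounds shown hold only methyl and phenyl on this carbonyl carbon, so it stays open whether a longer chain such as propyl, or a saturated ring such as cyclohexyl, would go with a similar number. As far as these compounds go, it also stays open how a phenyl carrying an amine or a carboxylic acid would read in this assay.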